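Ring Expansion Beside the Amino Group

This account rests on a few compounds, and the source may have more. Where it says the series, first, only, none or still open, it means among the compounds named here.

Compound 2 `COc1cccc(-c2c(C)n(Cc3c(F)cccc3F)c(=O)n(C[C@H](N)C3CCCC3)c2=O)c1F` stands lowest of the two numbers in an assay on HEK293 cells for binding affinity to Gonadotropin-releasing hormone receptor (Homo sapiens), read by radioligand binding (a lower number here means a stronger inhibitor, a higher number a weaker inhibitor), where compound 2 gives 10 nM. Compound 1 `COc1cccc(-c2c(C)n(Cc3c(F)cccc3F)c(=O)n(C[C@@H](N)C3CCCC3)c2=O)c1F` gives 94 nM in this assay; the step of a 9.4-fold lower number from compound 1 to compound 2 (0.97 log units; beyond the scatter) rests on (the fact that compounds 1 and 2 differ only in the configuration as drawn). Compound 3 `COc1cccc(-c2c(C)n(Cc3c(F)cccc3F)c(=O)n(C[C@@H](N)C3CCCCC3)c2=O)c1F` carries amino(cyclohexyl)methyl in place of amino(cyclopentyl)methyl on a saturated chain carbon bound to an aromatic nitrogen. Within the data shown here, no measured step touches ring size; the one known step concerns configuration, so the drawn stereocentre of compound 3 adds uncertainty. Compound 3 is expected to land near compound 2, the step of a 2.5-fold higher number from compound 2 to compound 3 (0.40 log units; beyond the scatter) small, at an estimated 25 nM with a range of 6 nM to 120 nM.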

Compound 3, inhibition constant: 46 nM
Compound 3: middle estimate off by 1.8-fold (0.26 log units), on the low side; low and high end bracket the measured number.
By their numbers in this assay, from the lowest: compound 2; then compound 3; then compound 1.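

In this assay, the drawn configuration of compound 1 is kept in compound 3, and cyclohexyl in place of cyclopentyl gives a 2.0-fold lower number from compound 1 to compound 3 (0.31 log units; beyond the scatter). The larger step, a 4.6-fold higher number from compound 2 to compound 3 (0.66 log units; beyond the scatter), joins ring size and drawn configuration in one change, and the two cannot be separated here. Ring size alone therefore moves the number at this position, yet compound 3 stays weaker than compound 2. Still open, on these data alone, is how the cyclohexyl compound with the opposite drawn configuration would read, and whether a cycloheptyl, phenyl or isopropyl group would be tolerated in place of these rings.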